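The source may report more compounds than this note shows. Statements on the series, on what has been measured and on what is new or still open speak of the compounds shown alone.

Measured so far:
compound 1, `CCCCn1ccc(N2CCN(c3nc(C)cc(C)n3)CC2)c(C#N)c1=O`, in a functional assay on CHO cells with metabotropic glutamate receptor 2 (Homo sapiens) as the target, read by GTPgammaS binding (a lower number here means that less compound is needed, a higher number that more compound is needed for the effect), gives 631 nM
compound 2, `Cc1cc(C)nc(N2CCN(c3ccn4c(CC(F)(F)F)cnc4c3C#N)CC2)n1`, in this assay gives 447 nM
compound 3, `CC(C)(C)c1ccc(-c2ccn3c(CC(F)(F)F)cnc3c2C#N)cc1`, in this assay gives 447 nM

Compound 2 sits level with compound 3 at the digits shown, and the gap to compound 1 is also within the usual scatter of repeated measurements, so the three numbers cannot be told apart on what is in hand. Among the compounds with values here, no step between measured compounds that differ in one place has been recorded, so nothing in this small set says how a change on the saturated chain carbon bound to an aromatic carbon moves the read-out.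

The next compound is compound 4, `CCc1cnc2c(C#N)c(N3CCN(c4nc(C)cc(C)n4)CC3)ccn12`. It differs from compound 2 in one place: methyl in place of trifluoromethyl on a saturated chain carbon bound to an aromatic carbon. The same difference, cut one bond further out, reads 2,2,2-trifluoroethyl to ethyl.

Within the data shown here, with no measured step of this kind to lean on, the expectation for compound 4 is anchored on compound 2 and its 447 nM, with no movement beyond the scatter assumed in either direction. On that basis compound 4 is estimated at 500 nM, within 150 nM to 1600 nM. The step this implies, a 1.1-fold higher number from compound 2 to compound 4 (0.05 log units; within the scatter), is expected to be no more than the scatter.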

Compound 4, half-maximal effective concentration: 2290 nM
Estimate against measurement, compound 4: 4.6-fold (0.66 log units) below; the whole stated range lies below it.
By their numbers in this assay, from the lowest: compounds 2, 3 and 1 (each within the scatter of the next); then compound 4.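

In this assay, within the data shown here, this is the first step that changes one place only, and it shows that the place is not silent: methyl in place of trifluoromethyl on a saturated chain carbon bound to an aromatic carbon gives a 5.1-fold higher number from compound 2 to compound 4 (0.71 log units; beyond the scatter). The earlier compounds shown here could not be told apart and gave no reading on this position, whereas here the 2,2,2-trifluoroethyl to ethyl change separates a pair beyond the scatter, with the 2,2,2-trifluoroethyl compound holding the lower number, though this rests on a single pair with all else held constant. No measurement in hand accounts for the size or direction of this step.

From the compounds shown here alone, it remains open whether the read-out tracks the fluorine atoms themselves or the larger group as a whole, and an ethyl chain carrying a single fluorine, or a longer chain such as propyl, would show where such groups fall relative to compound 2 and compound 4. Going by these compounds, it is equally open whether the same step would recur on compound 3, where the piperazine-linked part of compound 2 is replaced.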